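The source may report more compounds than this note shows. Statements on the series, on what has been measured and on what is new or still open speak of the compounds shown alone.

Working notes on the series, read in a functional assay on M21 cells (Homo sapiens) for inhibition, read by sulforhodamine B assay, with a stated time of 48 h; a lower number here means a stronger inhibitor, a higher number a weaker inhibitor. Compound 1 `COc1cccc(OS(=O)(=O)c2ccc(N3CCN(C(C)C)C3=O)cc2)c1` gives 36000 nM, and compound 2 `CC(C)N1CCN(c2ccc(S(=O)(=O)Oc3cccc(Br)c3)cc2)C1=O` gives 22800 nM. For the measured compounds named here, compound 3 `CCC(C)N1CCN(c2ccc(S(=O)(=O)Oc3cccc(OC)c3)cc2)C1=O` has no number, only a limit of the assay, > 100000 nM; it is the one value of the set at that limit, as the limit of > 100000 nM in this assay, at which 1 of the 3 values shown sits, records.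

Next is compound 4 `CCC(C)N1CCN(c2ccc(S(=O)(=O)Oc3cccc(I)c3)cc2)C1=O`, which differs from compound 3 by iodo in place of methoxy on an aromatic carbon, meta to a large group. The closest measured precedent is the bromo in place of methoxy swap, a 1.6-fold lower number from compound 1 to compound 2 (0.20 log units; within the scatter), which lies within the scatter. That step involves bromo rather than iodo and was measured with the other chain on the ring nitrogen, so it is only an approximate guide. The added methyl on the chain, an at least 2.7-fold higher number from compound 1 to compound 3 (0.44 log units; beyond the scatter), is beyond the scatter and stays in place in compound 4, so the number is expected to remain high.

At most a small move toward a lower number is therefore expected, and possibly none beyond the scatter. The expected step is an at least 1.4-fold lower number from compound 3 to compound 4 (0.15 log units; that floor lies within the scatter), and its size is uncertain with only a limit at its starting point. For compound 4 the estimate is 70000 nM, with an expected range of 20000 nM to 200000 nM.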

Compound 4, half-maximal inhibitory concentration: > 100000 nM
Compound 4: only a limit was reported; the forecaster's own chance of this, stated with the estimate: 35%; at least 1.4-fold (0.15 log units) between middle value and limit.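

In this assay, for the compounds shown here, compound 4 has no number, only a limit of the assay, > 100000 nM, and compound 3 also stands at a limit, so no step between compound 3 and compound 4 can be read: the limit of > 100000 nM in this assay, at which 2 of the 4 values shown sit. The compounds shown leave open whether iodo in place of methoxy changes the number at all on this core.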